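Cyclohexyl in Place of Propyl on Compound 1

A few compounds are considered here, and "the series" means these few. Any claim that something is new, unique, unknown or untested is made for them only; others in the source may bear on it.

Of the compounds shown here, three built on a shared core have been measured in an ADME assay on a cell-free system (plasma, Homo sapiens) for metabolic stability, with a stated time of 90 min; on this read-out higher numbers stand for a more stable compound and lower numbers for a less stable compound. Compound 1 `CCCC(=O)NCCCCCC(=O)N[C@H](C(=O)N1C[C@H](O)C[C@H]1C(=O)NCc1ccc(-c2scnc2C)cc1)C(C)(C)C` gives 83%, the second highest of the three numbers. Compound 3 `Cc1ncsc1-c1ccc(CNC(=O)[C@@H]2C[C@@H](O)CN2C(=O)[C@@H](NC(=O)CCCCCOC(=O)CC(c2ccccc2)c2ccccc2)C(C)(C)C)cc1` stands nearest at 58%, lower than compound 1 by more than the scatter. Compound 2 `Cc1ncsc1-c1ccc(CNC(=O)[C@@H]2C[C@@H](O)CN2C(=O)[C@@H](NC(=O)CCCCCNC(=O)CC(c2ccccc2)c2ccccc2)C(C)(C)C)cc1` stands furthest at 149%, higher than compound 1 by more than the scatter.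

The next compound in this account is compound 4 `Cc1ncsc1-c1ccc(CNC(=O)[C@@H]2C[C@@H](O)CN2C(=O)[C@@H](NC(=O)CCCCCNC(=O)C2CCCCC2)C(C)(C)C)cc1`, which carries cyclohexyl in place of propyl on a carbonyl carbon. For the measured compounds named here, no two measured compounds are available as a single-change comparison, so this step has no direct precedent in this assay. The expectation starts from compound 1 at 83% and leans more loosely on compound 2 at 149%, whose end group is also larger than propyl. Only a small upward step, not clearly beyond the scatter, is expected: a number 9 percentage points higher from compound 1 to compound 4 (within the scatter). With so little to go on, the range is kept wide. For compound 4 the estimated value is 92%, with an expected range from 70% to 120%.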

Compound 4, percent of the compound remaining: 168%
Compound 4: the middle estimate sits 76 percentage points below what was measured, outside the stated range (above it).
By their numbers in this assay, from the lowest: compound 3; then compound 1; then compound 2; then compound 4.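

In this assay, for the compounds shown here, placing cyclohexyl in place of propyl on a carbonyl carbon gives a number 85 percentage points higher from compound 1 to compound 4 (beyond the scatter) and so provides the first single-change comparison in this account. It shows that the read-out is highly sensitive to the group at this position, even though the change adds no hydrogen-bond donor or acceptor and no net charge, and both the entering and the leaving group consist of carbon only. What the change adds by the count is three heavy carbon atoms and one six-membered non-aromatic ring, yet nothing at hand bears on why the number moves so far.

This single pair cannot separate the effect of the ring from that of the larger carbon count, and a hexyl chain on the same carbonyl carbon would draw that distinction, while a cyclopentyl or phenyl ring would show whether ring size or ring type matters. As far as these compounds go, it also remains open whether the same exchange would produce a comparable step on a chain joined through an ester, as in compound 3, rather than through the amide-type nitrogen of compound 1.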